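This account rests on a few compounds, and the source may have more. Where it says the series, first, only, none or still open, it means among the compounds named here.

In an ADME assay on THP-1 cells (Homo sapiens) for cytotoxicity (a lower number here means that less compound is tolerated, a higher number that more compound is tolerated), three compounds carry a result. Compound 1 `Clc1ccc2nc(-c3ccccn3)c(Nc3ccc4c(c3)OCCO4)n2c1` reaches only a limit of the assay, > 50000 nM. Compound 2 `c1ccc(-c2nc3ccccn3c2NC2CCOC2)nc1` likewise reaches only a limit, > 50000 nM. Compound 3 `COc1ccn2c(Nc3ccccc3F)c(-c3ccccn3)nc2c1` gives 5750 nM. This is the only number shown, and compound 3 therefore stands alone with a measured half-maximal cytotoxic concentration, the other two values sitting at the limit of > 50000 nM in this assay, at which 2 of the 3 values shown sit.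

Compound 4 `COc1ccn2c(Nc3cc(F)cc(F)c3)c(-c3ccccn3)nc2c1` has not yet been measured. It differs from compound 3 in one place: 3,5-difluorophenyl in place of 2-fluorophenyl on a nitrogen on an aromatic ring. For the measured compounds named here, no step between measured compounds is available to set the size of this kind of change, and nothing among the three results speaks for a shift in either direction. The step from compound 3 to compound 4 is expected to stay within the usual scatter, a 1.0-fold higher number from compound 3 to compound 4 (0.02 log units; within the scatter). For compound 4 the estimate in this assay is 6000 nM, with a range from 2000 nM to 25000 nM.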

Compound 4, half-maximal cytotoxic concentration: 4300 nM
Estimate against measurement, compound 4: 1.4-fold (0.14 log units) above, within the range that was stated.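

In this assay, for the compounds shown here, putting 3,5-difluorophenyl in place of 2-fluorophenyl on a nitrogen on an aromatic ring gives a 1.3-fold lower number from compound 3 to compound 4 (0.13 log units; within the scatter), the first step that can be read at this position. Compound 3 and compound 4 therefore cannot be told apart in this read-out: a second fluorine and a different fluorine pattern on the phenyl ring leave the result within the scatter. Nothing measured here points to a cause for this outcome.

On these data alone, it remains open whether a different kind of group at this position, such as an amine or a carboxylic acid in place of the fluorines, would shift the number beyond the scatter. Compound 1 and compound 2 differ from compound 3 in more than one place, so the steps to them cannot be read.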